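Methyl for fluoro on compound 3

This account rests on a few compounds, and the source may have more. Where it says the series, first, only, none or still open, it means among the compounds named here.

In a functional assay on THP-1 cells (Homo sapiens) for inhibition, read by sulforhodamine B assay, with a stated time of 48 h (a higher number here means a weaker inhibitor, a lower number a stronger inhibitor), compound 1 `COC(=O)[C@@]1(C)C[C@@H](c2coc3ccc(Br)cc3c2=O)N(c2ccccc2)O1` gives 14700 nM and compound 3 `COC(=O)[C@@]1(C)C[C@@H](c2coc3ccc(F)cc3c2=O)N(c2ccccc2)O1` gives 47000 nM as the higher of the two numbers. Compound 2 `CCO[C@H]1C[C@@H](c2coc3ccc(F)cc3c2=O)N(c2ccccc2)O1` stands at > 60000 nM as a limit of the assay and not a number. Compound 4 `COC(=O)[C@@]1(C)C[C@@H](c2coc3ccc(C)cc3c2=O)N(c2ccccc2)O1` has methyl in place of fluoro on an aromatic carbon of compound 3 (methyl in place of fluoro on an aromatic carbon). Among the measured compounds shown here, the only measured step at that carbon is a 3.2-fold higher number from compound 1 to compound 3 (0.50 log units; beyond the scatter) with fluoro in place of bromo. Leaving fluoro is therefore expected to give a lower number in this assay with a step similar to or smaller than that one. The estimated change is a 2.1-fold lower number from compound 3 to compound 4 (0.33 log units; beyond the scatter) and remains uncertain. Compound 4 is estimated at 22000 nM with an expected range from 9000 nM to 55000 nM in this read-out.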

Compound 4, half-maximal inhibitory concentration: 7300 nM
The estimate for compound 4 lay 3.0-fold (0.48 log units) above the measured number; measured number below the stated range.
By their numbers in this assay, from the lowest: compounds 4 and 1 (each within the scatter of the next); then compound 3. At a limit, above all of these: compound 2.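

In this assay methyl in place of fluoro gives a 6.4-fold lower number from compound 3 to compound 4 (0.81 log units; beyond the scatter) and so shows that a second group at this aromatic carbon, besides bromo, gives a lower number than fluoro. Methyl in place of bromo gives a 2.0-fold lower number from compound 1 to compound 4 (0.30 log units; within the scatter) and so does not separate these two groups. Nothing measured here bears on the cause of this result. On these data alone, whether a methoxy group, an amine or a carboxylic acid at this carbon would stay with methyl and bromo or fall with fluoro remains open.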